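Swapping the ether arm of compound 3 for a carboxylic acid

The source may report more compounds than this note shows. Statements on the series, on what has been measured and on what is new or still open speak of the compounds shown alone.

Of the compounds shown here, three with the same fused core have been tested in a functional assay for inhibition of nuclear factor NF-kappa-B complex (Homo sapiens); a lower number here means a stronger inhibitor, a higher number a weaker inhibitor. Compound 1 `COc1ccc2c(c1)OC(c1cc(OC)c(OC)c(OC)c1)C(C(=O)N(C)OC)=C2` gives 11700 nM. Compound 2 `COc1ccc2c(c1)OC(c1cc(OC)c(OC)c(OC)c1)C(C(=O)OCCc1ccccc1)=C2` gives 16200 nM. Compound 3 `CCOCC1=Cc2ccc(OC)cc2OC1c1cc(OC)c(OC)c(OC)c1` gives 21300 nM. The three numbers lie close together: a 1.4-fold higher number from compound 1 to compound 2 (0.14 log units; within the scatter), a 1.8-fold higher number from compound 1 to compound 3 (0.26 log units; within the scatter) and a 1.3-fold higher number from compound 2 to compound 3 (0.12 log units; within the scatter). Compound 3 thus shows the highest of the three numbers, yet its gaps to compound 2 and to compound 1 are both within the scatter, so the three are not separable on this evidence.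

Compound 4 `COc1ccc2c(c1)OC(c1cc(OC)c(OC)c(OC)c1)C(C(=O)O)=C2` differs from compound 3 in one place: carboxy in place of ethoxymethyl on a double-bonded ring carbon. The steps that speak to this change are those that exchanged the group on the same double-bonded ring carbon, from compound 1 to compound 3 and from compound 2 to compound 3, and both stayed within the scatter. Three quite different groups at that position have given numbers that cannot be told apart, which suggests that this position tolerates change without moving this assay much. The carboxy group is new to the set, so some uncertainty remains.

For compound 4 the expected result in this assay is 18000 nM, with a range from 6000 nM to 55000 nM. The step from compound 3 to compound 4 is expected to be a 1.2-fold lower number from compound 3 to compound 4 (0.07 log units; within the scatter), which would be within the scatter.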

Compound 4, half-maximal inhibitory concentration: > 50000 nM
Compound 4: a limit, no number (the forecaster's own chance of this, stated with the estimate: 20%); middle value at least 2.7-fold (0.44 log units) away from the limit.
By their numbers in this assay, from the lowest: compounds 1, 2 and 3 (each within the scatter of the next). At a limit, above all of these: compound 4.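

In this assay the reading for compound 4 is a limit of the assay and not a number: the limit of > 50000 nM in this assay, at which 1 of the 4 values shown sits.

Even so, the double-bonded ring carbon does not accept every group equally, since the change to carboxy gives an at least 2.3-fold higher number from compound 3 to compound 4 (0.37 log units; beyond the scatter), the loss of phenethyl from the ester gives an at least 3.0-fold higher number from compound 2 to compound 4 (0.48 log units; beyond the scatter), and the replacement of methoxy(methyl)amino on the carbonyl carbon gives an at least 4.2-fold higher number from compound 1 to compound 4 (0.63 log units; beyond the scatter). All three steps lie beyond the scatter, whereas the exchanges among compound 1, compound 2 and compound 3 stayed within it, so the tolerance suggested by those three compounds does not extend to carboxy.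

As far as these compounds go, how far compound 4 really lies from the other compounds stays unknown, as each of these steps gives only a minimum size. The compounds shown also leave open whether this weaker result is specific to the free carboxylic acid, or whether a primary amide, a hydroxymethyl group or an amine on the same carbon would give a similarly weak result.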